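The source may report more compounds than this note shows. Statements on the series, on what has been measured and on what is new or still open speak of the compounds shown alone.

In an assay on HEK293 cells for displacement of a labelled ligand from 5-hydroxytryptamine receptor 7 (Homo sapiens), read by radioligand binding, with a stated time of 1 h (on this read-out higher numbers stand for weaker inhibition and lower numbers for stronger inhibition), the three measured compounds gave:
compound 1 `CN1CCN(c2nc(N)nc(COc3cccc(Cl)c3)n2)CC1`, 5820 nM
compound 2 `Cc1ccc(OCc2nc(N)nc(N3CCN(C)CC3)n2)cc1`, 16100 nM
compound 3 `Cc1cc(Cl)ccc1OCc1nc(N)nc(N2CCN(C)CC2)n1`, 15200 nM

Among these, compound 3 sits with compound 2: the step of a 1.1-fold lower number from compound 2 to compound 3 (0.02 log units; within the scatter) lies within the scatter, while compound 1 is clearly apart, as the step of a 2.6-fold higher number from compound 1 to compound 3 (0.42 log units; beyond the scatter) shows. Compound 4 `Cc1cc(OCc2nc(N)nc(N3CCN(C)CC3)n2)ccc1Cl` differs from compound 3 by 4-chloro-3-methylphenyl in place of 4-chloro-2-methylphenyl on an oxygen on a saturated carbon. Among the compounds with values here, no measured step moves a methyl around the ring in this way; the nearest guide is the step from compound 2 to compound 3, where adding chlorine and shifting methyl changed nothing beyond the scatter. Accordingly, compound 4 is expected to remain near compound 3, with a step of a 1.2-fold lower number from compound 3 to compound 4 (0.07 log units; within the scatter), and its estimated value in this assay is 13000 nM, between 6000 nM and 30000 nM.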

Compound 4, inhibition constant: 5840 nM
Estimate against measurement, compound 4: 2.2-fold (0.35 log units) above; the measured number lies below the stated range.
By their numbers in this assay, from the lowest: compounds 1 and 4 (each within the scatter of the next); then compounds 3 and 2 (each within the scatter of the next).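

In this assay, the same atoms joined differently matter at this place: 4-chloro-3-methylphenyl in place of 4-chloro-2-methylphenyl gives a 2.6-fold lower number from compound 3 to compound 4 (0.42 log units; beyond the scatter) and so separates two groups that differ only in the arrangement of their atoms. The same group in place of 4-methylphenyl gives a 2.8-fold lower number from compound 2 to compound 4 (0.44 log units; beyond the scatter) as a step of similar size, while in place of 3-chlorophenyl it gives a 1.0-fold higher number from compound 1 to compound 4 (0.00 log units; within the scatter) with no separation. Nothing measured here explains these differences. As far as these compounds go, whether a methoxy group or an amine in place of that methyl would keep the number of compound 4 stays open.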